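The source may report more compounds than this note shows. Statements on the series, on what has been measured and on what is new or still open speak of the compounds shown alone.

Compound 2 `C#CCOC(=O)/C(C)=C/CC/C(C)=C/CC/C(C)=C/CC[C@@H]1[C@@]2(C)CCC(=O)C(C)(C)[C@H]2CC[C@@]1(C)O` gives 46100 nM in a functional assay on DU-145 cells (Homo sapiens) for antiproliferative activity, read by MTT assay, with a stated time of 48 h; on this read-out lower numbers stand for stronger inhibition and higher numbers for weaker inhibition. Compound 3 `C/C(=C\CC/C(C)=C/CC[C@@H]1[C@@]2(C)CCC(=O)C(C)(C)[C@H]2CC[C@@]1(C)O)CC/C=C(\C)C(=O)OCc1cn(-c2cccc(C)c2)nn1` gives 137000 nM in this assay. Compound 1 `C/C(=C\CC/C(C)=C/CC[C@@H]1[C@@]2(C)CCC(=O)C(C)(C)[C@H]2CC[C@@]1(C)O)CC/C=C(\C)C(=O)OCc1cn(-c2ccccc2Br)nn1` sits at a limit of this assay, > 150000 nM, not a measured number.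

Among the two numbers given, compound 2 stands lowest, with compound 3 nearest at a 3.0-fold higher number from compound 2 to compound 3 (0.47 log units; beyond the scatter). Compound 4 `C/C(=C\CC/C(C)=C/CC[C@@H]1[C@@]2(C)CCC(=O)C(C)(C)[C@H]2CC[C@@]1(C)O)CC/C=C(\C)C(=O)OCc1cn(-c2ccccc2)nn1` has not yet been measured; it differs from compound 2 in one place: 1-phenyl-1H-1,2,3-triazol-4-yl in place of ethynyl on a saturated chain carbon bound to an oxygen next to a carbonyl group. The measured step that bears on this change is a 3.0-fold higher number from compound 2 to compound 3 (0.47 log units; beyond the scatter), where a 1-(3-methylphenyl)-1H-1,2,3-triazol-4-yl replaced the same ethynyl; compound 1, with a 2-bromophenyl on that triazole, reached only the limit (the limit of > 150000 nM in this assay, at which 1 of the 3 values shown sits). For compound 4, carrying the plain phenyl, a comparable rise is expected: a 2.8-fold higher number from compound 2 to compound 4 (0.45 log units; beyond the scatter). Compound 4 is therefore estimated at 130000 nM, within a range from 55000 nM to 300000 nM.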

Compound 4, half-maximal inhibitory concentration: 95500 nM
Estimate against measurement, compound 4: 1.4-fold (0.13 log units) above; the range from low to high includes it.
By their numbers in this assay, from the lowest: compound 2; then compounds 4 and 3 (each within the scatter of the next). At a limit, above all of these: compound 1.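

Replacing propargyl with (1-phenyl-1H-1,2,3-triazol-4-yl)methyl raises the number even without a substituent on the phenyl ring: a 2.1-fold higher number from compound 2 to compound 4 (0.32 log units; beyond the scatter). The methyl of compound 3 is therefore not needed for this rise. Hydrogen in place of methyl on an aromatic carbon gives a step that lies within the scatter: a 1.4-fold lower number from compound 3 to compound 4 (0.16 log units; within the scatter). Hydrogen in place of bromo on an aromatic carbon gives only a floor that lies within the scatter: an at least 1.5-fold lower number from compound 1 to compound 4 (0.19 log units; that floor lies within the scatter). Compound 1 stands at a limit, so this step cannot be read: the limit of > 150000 nM in this assay, at which 1 of the 4 values shown sits.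

Still open, going by these compounds, is whether an amine or a carboxylic acid on the phenyl ring would bring the number back towards that of compound 2. On these data alone, the effect of a shorter or longer chain between the ester oxygen and the triazole also remains unknown.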